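Chloro Substitution on the Aryl Ring: Compound 3 to 4

A few compounds are considered here, and "the series" means these few. Any claim that something is new, unique, unknown or untested is made for them only; others in the source may bear on it.

The series shares a core seen in compound 1 `O=C(CCc1nnc(-c2ccccc2Cl)o1)c1ccccc1`, which in a functional assay on the whole organism (strain Wistar) for inhibition, with Rattus norvegicus as the target, with stated times of 30 min and 3 h, at a dose of 20 mg/kg by the oral route (a higher number here means more inhibition at the dose given (going by the name of the read-out), a lower number less inhibition), gives 35.8%. Going by the values given here, compound 2 `Cc1ccc(C(=O)CCc2nnc(-c3ccccc3Cl)o2)cc1` gives 57.3%, and the step of a number 21.5 percentage points higher from compound 1 to compound 2 (beyond the scatter) is the only single-point change measured so far. Compound 3 `Cc1ccc(C(=O)CCc2nnc(-c3ccccc3)o2)c(C)c1` gives 58%, the highest of the three numbers, though its gap to compound 2 lies within the scatter; compound 2 and compound 3 differ in two places, so their two values say only that they sit close together.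

Compound 4 `Cc1ccc(C(=O)CCc2nnc(-c3ccccc3Cl)o2)c(C)c1` differs from compound 3 by chloro in place of hydrogen on an aromatic carbon. Among the compounds with values here, no measured step covers this change on its own, and the methyl step between compound 1 and compound 2 sits on the other ring, so it bears on it only loosely. The closeness of compound 2 and compound 3 suggests no step beyond the scatter is expected in this assay, giving an expected no change at the digits printed from compound 3 to compound 4 (within the scatter). Compound 4 is therefore estimated at 58%, within 42% to 72%.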

Compound 4, a percentage reported as inhibition, in the whole organism at one dose (the size of the read-out at that dose, not a potency): 60.5%
For compound 4 the middle estimate is 2.5 percentage points below the measured one; the measured number falls inside the stated range.
By their numbers in this assay, from the lowest: compound 1; then compounds 2, 3 and 4 (each within the scatter of the next).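

In this assay, going by these compounds alone, the change from phenyl to 2-chlorophenyl gives a number 2.5 percentage points higher from compound 3 to compound 4 (within the scatter) and so offers the first direct reading of chloro at this position, with the 2,4-dimethylphenyl group present on the carbonyl carbon. Within the data shown here, with the 2-chlorophenyl group held constant, the added methyl gives a number 3.2 percentage points higher from compound 2 to compound 4 (within the scatter) while the change from phenyl to 2,4-dimethylphenyl on the carbonyl carbon gives a number 24.7 percentage points higher from compound 1 to compound 4 (beyond the scatter) as the one step here that clears the scatter. Nothing measured here accounts for these steps.

Going by these compounds, it remains open whether chloro in place of hydrogen reads the same when the ring on the carbonyl carbon is plain phenyl. The compounds shown also leave open how fluoro, methoxy or a carboxylic acid would read in place of chloro.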